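The source may report more compounds than this note shows. Statements on the series, on what has been measured and on what is new or still open speak of the compounds shown alone.

Compound 1, `Cn1c(-c2ccccc2C(F)(F)F)nnc1C12CCC(CCS(C)(=O)=O)(CC1)CC2`: 96%
Compound 2, `Cn1c(-c2ccccc2C(F)(F)F)nnc1C12CCC(CCS(=O)(=O)C(C)(C)C)(CC1)CC2`: 65%

Both compounds were tested in a functional assay on the whole organism (strain ICR) for inhibition, with Mus musculus as the target, with a stated time of 4 h, at a dose of 10 mg/kg by the oral route; a higher number here means more inhibition at the dose given (going by the name of the read-out), a lower number less inhibition. Among the compounds with values here, compound 2 stands lowest of the two numbers; the only measured step, a number 31 percentage points lower from compound 1 to compound 2 (beyond the scatter), separates it from compound 1, and it is beyond the scatter. Compound 3, `Cn1c(-c2ccccc2C(F)(F)F)nnc1C12CCC(CNS(C)(=O)=O)(CC1)CC2`, is not yet measured in this assay. It differs from compound 2 in a single place: methanesulfonamido in place of ((tert-butyl)sulfonyl)methyl on a saturated chain carbon bound to a saturated ring carbon. Within the data shown here, the one measured step bears on this change in part, since compound 3 returns to a methyl on the sulfonyl sulfur, as in compound 1, which gave the higher number, while the chain carbon next to the sulfur is exchanged for a sulfonamide nitrogen, a change for which no step has been measured. The expectation is therefore a rise from compound 2 back toward compound 1, beyond the scatter, but with wide uncertainty from the untested part of the change. Compound 3 is expected to give 82%, with an estimated range from 55% to 98%. The expected step is a number 17 percentage points higher from compound 2 to compound 3 (beyond the scatter).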

Compound 3, a percentage reported as inhibition, in the whole organism at one dose (the size of the read-out at that dose, not a potency): 73%
The estimate for compound 3 lay 9 percentage points above the measured number, within the range that was stated.
By their numbers in this assay, from the lowest: compounds 2 and 3 (each within the scatter of the next); then compound 1.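

In this assay, the sulfonamide nitrogen matters even when the methyl on the sulfonyl sulfur is kept: methanesulfonamido in place of (methylsulfonyl)methyl gives a number 23 percentage points lower from compound 1 to compound 3 (beyond the scatter). Within the data shown here, until now, the only measured change at this position was the group on the sulfur, so this shows that the link joining the sulfonyl group to the saturated ring carbon also affects the result. The second step, a number 8 percentage points higher from compound 2 to compound 3 (within the scatter), shows that compound 2 and compound 3 cannot be told apart here, so two quite different changes to compound 1, one on the sulfur and one in the chain, end up within the scatter of each other.

Nothing measured here explains these differences. Still open, on these data alone, is whether a longer chain carrying the methanesulfonamido group, or an amine or a carboxylic acid on the saturated chain carbon, would match compound 1, and whether the differences seen at this one dose would hold at other doses.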